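Changing the Ester Group: From Compound 2 to Compound 4

A few compounds are considered here, and "the series" means these few. Any claim that something is new, unique, unknown or untested is made for them only; others in the source may bear on it.

Compound 1, `CCCc1nc(CC)c(C(=O)OCC(=O)c2ccccc2)n1Cc1ccc(-c2ccccc2S(=O)(=O)NC(=O)OCCC(C)C)cc1F`, gives 2 nM in an assay on isolated protein for binding affinity to Type-2 angiotensin II receptor (Homo sapiens); on this read-out higher numbers stand for weaker inhibition and lower numbers for stronger inhibition.
Compound 2, `CCCc1nc(CC)c(C(=O)OCc2ccccc2OC)n1Cc1ccc(-c2ccccc2S(=O)(=O)NC(=O)OCCC(C)C)cc1F`, gives 1 nM in this assay.
Compound 3, `CCCc1nc(CC)c(C(=O)OCCN2C(=O)c3ccccc3C2=O)n1Cc1ccc(-c2ccccc2S(=O)(=O)NC(=O)OCCC(C)C)cc1F`, gives 7 nM in this assay.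

Compound 2 has the lowest number of the three in this assay; compound 1 sits within the scatter of it, while compound 3 lies beyond the scatter. Compound 4, `CCCc1nc(CC)c(C(=O)OCc2ccccc2NC(=O)c2ccccc2)n1Cc1ccc(-c2ccccc2S(=O)(=O)NC(=O)OCCC(C)C)cc1F`, differs from compound 2 in one place: benzamido in place of methoxy on an aromatic carbon, ortho to a large group. The measured steps that touch this part of the molecule all change the group on the saturated chain carbon bound to the ester oxygen. The step of a 2.0-fold lower number from compound 1 to compound 2 (0.30 log units; within the scatter) stayed within the scatter, whereas a 7.0-fold higher number from compound 2 to compound 3 (0.85 log units; beyond the scatter) and a 3.5-fold higher number from compound 1 to compound 3 (0.54 log units; beyond the scatter) went the other way, with the bulkier group giving the higher number. The change to compound 4 enlarges the group in a similar way, so a modest upward step in this assay is expected, a 3.0-fold higher number from compound 2 to compound 4 (0.48 log units; beyond the scatter). Compound 4 is therefore estimated at 3 nM, with a range from 1 nM to 10 nM.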

Compound 4, half-maximal inhibitory concentration: 1 nM
Compound 4: middle estimate off by 3.0-fold (0.48 log units), on the high side, and the stated range covers the measured number.
By their numbers in this assay, from the lowest: compounds 2, 4 and 1 (each within the scatter of the next); then compound 3.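

In this assay, benzamido in place of methoxy gives no change at the digits printed from compound 2 to compound 4 (within the scatter), so this aromatic carbon accepts the larger group, with its added aromatic ring and hydrogen-bond donor, without the number moving beyond the scatter. The earlier steps shown here all exchanged the whole group on the saturated chain carbon, and the higher number of compound 3 had linked the larger group with weaker inhibition; compound 4 goes against that link, so it does not carry over to a larger group on this aromatic carbon. The compounds shown leave open whether an amine or a carboxylic acid on this aromatic carbon would also keep the number in this range. They also leave open whether a simple acetamido group would do the same as benzamido. No measurement given here bears on why the number holds at this position.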